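This account rests on a few compounds, and the source may have more. Where it says the series, first, only, none or still open, it means among the compounds named here.

The set rests on one shared core, which in compound 1 carries a 2-fluorophenyl group on the sulfonyl sulfur, `O=S(=O)(Nc1ccc2oc(-c3ccccc3)nc2c1)c1ccccc1F`. In an assay on isolated protein for inhibition of malate dehydrogenase, mitochondrial (Sus scrofa), with stated times of 45 min and 30 min (a higher number here means a weaker inhibitor, a lower number a stronger inhibitor), compound 1 reaches only the limit of the assay, > 63000 nM. Compound 2, `O=S(=O)(Nc1ccc2oc(-c3ccccc3)nc2c1)c1cccs1`, has a thiophen-2-yl group at that position. In this assay compound 2 again returns a limit and no number, > 63000 nM. Compound 3, `O=S(=O)(Nc1ccc2oc(-c3ccccc3)nc2c1)c1ccc(Cl)c(Cl)c1`, carries a 3,4-dichlorophenyl group there. In this assay compound 3 likewise gives a limit rather than a number, > 63000 nM. So compound 3 stands where every measured member of the set stands: all three values sit at the same limit, (the limit of > 63000 nM in this assay, at which 3 of the 3 values shown sit). The steps a step that the two limits leave unreadable from compound 1 to compound 2, a step that the two limits leave unreadable from compound 1 to compound 3 and a step that the two limits leave unreadable from compound 2 to compound 3 each join two limits and cannot be read in size. Compound 4, `Cc1cccc(S(=O)(=O)Nc2ccc3oc(-c4ccccc4)nc3c2)c1`, differs from compound 3 by one change: 3-methylphenyl in place of 3,4-dichlorophenyl on a sulfonyl sulfur. Because compound 3 sits at the limit of > 63000 nM in this assay, at which 3 of the 3 values shown sit, and no change at this sulfonyl sulfur has yet given a readable step, the 3-methylphenyl group is not expected to lift compound 4 off that limit. The step that the limit leaves unreadable from compound 3 to compound 4 is therefore expected to be none beyond the scatter. Compound 4 is expected to give 100000 nM in this assay, with a range from 30000 nM to 400000 nM.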

Compound 4, half-maximal inhibitory concentration: > 63000 nM
Compound 4 ended at the assay's limit; the forecaster's own chance of this, stated with the estimate: 85%; the middle value is on the limit's open side.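

In this assay compound 4 also gives only a limit, > 63000 nM, so its steps to compound 1, compound 2 and compound 3 cannot be read in size. All four compounds stand together: the limit of > 63000 nM in this assay, at which 4 of the 4 values shown sit. The compounds shown leave open whether any group on the sulfonyl sulfur can bring a readable number in this assay.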